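Fluoro ortho to the methoxy group: expected effect

A few compounds are considered here, and "the series" means these few. Any claim that something is new, unique, unknown or untested is made for them only; others in the source may bear on it.

Compound 1 `CC(C)CCn1ccc(-c2ccccc2)c(C#N)c1=O` carries an unsubstituted phenyl group on the shared core; in a functional assay on CHO cells for positive allosteric modulation of metabotropic glutamate receptor 2 (Homo sapiens), read by scintillation counting and GTPgammaS binding, with a stated time of 30 min (on this read-out lower numbers stand for an effect already at smaller amounts and higher numbers for an effect only at larger amounts of compound), compound 1 gives 8510 nM. Compound 2 `COc1ccc(-c2ccn(CCC(C)C)c(=O)c2C#N)cc1` adds a methoxy group to that ring, and in this assay compound 2 gives 1150 nM. Among the compounds with values here, the step of a 7.4-fold lower number from compound 1 to compound 2 (0.87 log units; beyond the scatter) is the only measured step, and it places compound 2 at the lower of the two numbers seen so far, beyond the scatter from compound 1.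

Compound 3 `COc1ccc(-c2ccn(CCC(C)C)c(=O)c2C#N)cc1F` differs from compound 2 by fluoro in place of hydrogen on an aromatic carbon, the fluoro sitting on an aromatic carbon ortho to the methoxy group and meta to a large group. Within the data shown here, no measured step shows a fluoro entering on this ring, so the methoxy step from compound 1 to compound 2 bears on it only by showing that this ring tolerates substitution with a gain in this assay. A single fluorine is a smaller change, so the expected step of a 1.4-fold lower number from compound 2 to compound 3 (0.16 log units; within the scatter) is small, toward a slightly lower number, and may stay within the scatter. Compound 3 is estimated at 800 nM in this assay, in the range 300 nM to 2500 nM.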

Compound 3, half-maximal effective concentration: 1170 nM
For compound 3 the middle estimate is 1.5-fold (0.17 log units) below the measured one, and the stated range covers the measured number.
By their numbers in this assay, from the lowest: compounds 2 and 3 (each within the scatter of the next); then compound 1.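

In this assay, fluoro in place of hydrogen on an aromatic carbon, ortho to a methoxy group and meta to a large group, gives a 1.0-fold higher number from compound 2 to compound 3 (0.01 log units; within the scatter), so compound 2 and compound 3 cannot be told apart at this position. Within the data shown here, the earlier step, a 7.4-fold lower number from compound 1 to compound 2 (0.87 log units; beyond the scatter), showed only that a methoxy group on this ring goes with a lower number; the new step adds that a fluoro can enter the same ring while the reading stays within the scatter of that of compound 2. No measurement is at hand that explains this result or bears on it.

On these data alone, whether chloro, methyl or a second methoxy group at this same position would also read within the scatter of compound 2 remains open, so one fluoro result does not define what this position accepts. As far as these compounds go, it is also open whether a fluoro would give a similarly flat step on the unsubstituted phenyl group of compound 1, where no methoxy group is present.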